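Ester to Acid on a Vitamin D Receptor Antagonist Core

The source may hold more compounds than are shown below. What is called first, only, known or untested is meant among the compounds shown, and "the series" means these compounds.

Compound 1 `COC(=O)c1cccc(OCc2oc(-c3ccccc3OC)nc2C)c1`: 7330 nM
Compound 2 `COC(=O)c1cccc(OCc2oc(-c3cccc(OC)c3)nc2C)c1`: 17100 nM
Compound 3 `COC(=O)CCc1ccc(OCc2oc(-c3ccccc3OC)nc2C)cc1`: 13600 nM

In an assay on cells for antagonist activity at vitamin D3 receptor (Homo sapiens), read by a luciferase reporter (on this read-out lower numbers stand for stronger inhibition and higher numbers for weaker inhibition), compound 1 gives the lowest of the three numbers. Compound 3 lies within the usual scatter of compound 1, so the two cannot be ranked, while the step of a 2.3-fold higher number from compound 1 to compound 2 (0.37 log units; beyond the scatter) reaches beyond the scatter. Compound 4 `COc1ccccc1-c1nc(C)c(COc2cccc(C(=O)O)c2)o1` differs from compound 1 by hydrogen in place of methyl on an oxygen next to a carbonyl group. Among the measured compounds shown here, no measured step touches this part of the molecule; the one measured step concerns the methoxyphenyl group, not the ester. For the measured compounds named here, with no direct precedent, the expected step of a 1.1-fold higher number from compound 1 to compound 4 (0.04 log units; within the scatter) is small and plausibly within the scatter, and the range must be wide. Compound 4 is estimated at 8000 nM, between 2500 nM and 25000 nM.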

Compound 4, half-maximal inhibitory concentration: > 100000 nM
Compound 4: only a limit was reported; the forecaster's own chance of this, stated with the estimate: 10%; at least 12-fold (1.09 log units) between middle value and limit.
By their numbers in this assay, from the lowest: compounds 1, 3 and 2 (each within the scatter of the next, the first and the last beyond it). At a limit, above all of these: compound 4.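

Compound 4 gives no exact number, only a limit: the limit of > 100000 nM in this assay, at which 1 of the 4 values shown sits.

Changing methoxycarbonyl to carboxy brings an at least 13-fold higher number from compound 1 to compound 4 (1.13 log units; beyond the scatter), the largest step seen so far. The earlier compounds shown here left the ester in place, and this pair shows that inhibition depends strongly on the methyl on this oxygen, since swapping that one carbon for hydrogen is enough to produce this step.

On these data alone, whether an amide or an ethyl ester in this place would keep the inhibition of compound 1 stays open. So does whether a carboxylic acid would give the same result on the chain of compound 3.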